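The source may hold more compounds than are shown below. What is called first, only, known or untested is meant among the compounds shown, and "the series" means these compounds.

Measured so far:
Compound 1, with structure `CC1(c2ccccc2)CCCN(Cc2ccn3c(CC4CC4)nnc3c2C(F)(F)F)C1`, gives 278% in an assay on CHO cells for positive allosteric modulation of metabotropic glutamate receptor 2 (Homo sapiens), read by scintillation counting, with a stated time of 30 min; a higher number here means a larger maximal response, a lower number a smaller maximal response.
Compound 2, with structure `Fc1cccc(F)c1N1CCN(Cc2ccn3c(CC4CC4)nnc3c2C(F)(F)F)CC1`, gives 366% in this assay.

Of these two numbers, compound 2 stands highest, and the gap down to compound 1 is beyond the usual scatter of this assay, so the two compounds genuinely differ in their maximal response. Among the compounds with values here, compound 1 and compound 2 differ at more than one place, so no single structural step between them is counted here, and nothing can be read from them about any one change.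

The next compound, compound 3, with structure `FC(F)(F)c1c(CN2CCN(c3ccc(Cl)cc3Cl)CC2)ccn2c(CC3CC3)nnc12`, keeps the shared core of compound 2 and changes only the ring on the amine nitrogen: 2,4-dichlorophenyl in place of 2,6-difluorophenyl on an amine nitrogen in a ring. No measured pair among the compounds shown makes this kind of swap, so any expectation rests on compound 2 alone. The exchange of one halogenated phenyl ring for another is expected to leave the response close to that of compound 2, with the step of a number 56 percentage points lower from compound 2 to compound 3 (beyond the scatter) estimated as a modest decrease. Compound 3 is therefore expected to reach about 310% in this assay, within a range from 220% to 400%.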

Compound 3, largest response reached (Emax), in percent of the reference or control that the assay uses: 262%
Beside the measured number, compound 3's estimate is 48 percentage points above it, within the range that was stated.
By their numbers in this assay, from the lowest: compound 3; then compound 1; then compound 2.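

Within the data shown here, exchanging 2,6-difluorophenyl for 2,4-dichlorophenyl on the amine nitrogen in a ring gives a number 104 percentage points lower from compound 2 to compound 3 (beyond the scatter) in this assay, the first single change that can be read on its own. It shows that the maximal response at this place depends on more than the presence of a halogenated phenyl ring: the leaving and entering groups have the same counts of heavy atoms, hydrogen-bond donors and hydrogen-bond acceptors, the same carbon-only aromatic ring and no net charge, yet the difference lies beyond the usual scatter. No measurement shown explains why the response differs between these two groups.

This one step changes both the kind of halogen and where the halogens sit, so it cannot tell which of the two matters, and compound 1 differs from both compounds in more than one place and cannot settle it. A 2,4-difluorophenyl or 2,6-dichlorophenyl group would separate those two changes, while a plain phenyl ring would show what the halogens contribute at all.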